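The source may hold more compounds than are shown below. What is called first, only, known or untested is meant among the compounds shown, and "the series" means these compounds.

Measured in a functional assay on U-251 cells (Homo sapiens) for inhibition, read by sulforhodamine B assay, with a stated time of 48 h; on this read-out lower numbers stand for higher toxicity in this test and higher numbers for lower toxicity in this test:
Compound 1, `COc1cc(-c2cc(/C=C/C(=O)c3ccc(N)cc3)[nH]n2)cc(OC)c1OC`, gives 5390 nM.
Compound 2, `COc1cc(-c2cc(/C=C/C(=O)c3ccc(Cl)c(Cl)c3)[nH]n2)cc(OC)c1OC`, gives only a limit, > 100000 nM.
Compound 3, `COc1ccc(C(=O)/C=C/c2cc(-c3cc(OC)c(OC)c(OC)c3)n[nH]2)cc1OC`, gives 4990 nM.

Compound 3 holds the lowest of the two numbers, though compound 1 sits within the scatter of it, as a 1.1-fold lower number from compound 1 to compound 3 (0.03 log units; within the scatter) shows. Compound 4, `COc1cc(-c2cc(/C=C/C(=O)c3ccc(F)c(F)c3)[nH]n2)cc(OC)c1OC`, differs from compound 3 by 3,4-difluorophenyl in place of 3,4-dimethoxyphenyl on a carbonyl carbon. The step that bears on this change is an at least 20-fold lower number from compound 2 to compound 3 (1.30 log units; beyond the scatter), where the 3,4-dichlorophenyl analogue, compound 2, sat at the limit of > 100000 nM in this assay, at which 1 of the 3 values shown sits. Compound 4 again carries a dihalogenated ring, so compound 4 is expected to give a higher number than compound 3, a step of an 8.0-fold higher number from compound 3 to compound 4 (0.90 log units; beyond the scatter). Compound 4 is estimated at 40000 nM, between 8000 nM and 200000 nM, with a fair chance that only a limit is reported.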

Compound 4, concentration lethal to 50% of the cells: > 100000 nM
Compound 4 gave a limit, no number; the forecaster's own chance of this, stated with the estimate: 40%; middle value at least 2.5-fold (0.39 log units) from the limit.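

In this assay compound 4 gives only a limit, not a number, which places the 3,4-difluorophenyl group with the 3,4-dichlorophenyl group: the limit of > 100000 nM in this assay, at which 2 of the 4 values shown sit. The change gives an at least 20-fold higher number from compound 3 to compound 4 (1.30 log units; beyond the scatter) and also an at least 18-fold higher number from compound 1 to compound 4 (1.26 log units; beyond the scatter), so on this carbonyl carbon the large step is no longer tied to chlorine alone among the compounds shown. Compound 2 and compound 4 both stand at limits, so the step between them cannot be read and the two halogens cannot be ordered. The compounds shown leave open where an unsubstituted phenyl group or a ring carrying a single methoxy group would fall.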